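A few compounds are considered here, and "the series" means these few. Any claim that something is new, unique, unknown or untested is made for them only; others in the source may bear on it.

The series shares one core, and compound 1 `CCC1(Cc2ccccc2)OS(=O)(=O)C=C1OCc1ccc(OC)cc1` carries a 4-methoxyphenyl group on a saturated chain carbon bound to an oxygen on an unsaturated carbon. In an ADME assay on HEL cells (Homo sapiens) for cytotoxicity, with a stated time of 3 days (a higher number here means that more compound is tolerated, a lower number that less compound is tolerated), compound 1 gives >= 200000 nM, which is a limit of the measurement and not a number. Compound 2 `CCC1(CC)OS(=O)(=O)C=C1OCc1ccccc1` is a second member of the set. In this assay compound 2 gives > 400000 nM, again a limit. Compound 3 `CCC1(Cc2ccccc2)OS(=O)(=O)C=C1OC(=O)c1ccccc1` completes the measured group. In this assay compound 3 gives > 400000 nM, once more a limit. For the measured compounds named here, compound 1 thus sits at the limit of >= 200000 nM in this assay, at which 1 of the 3 values shown sits, whereas the other two sit at the limit of > 400000 nM in this assay, at which 2 of the 3 values shown sit, so no defined step between measured compounds can be drawn.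

Compound 4 `CCC1(Cc2ccccc2)OS(=O)(=O)C=C1OCCCc1ccccc1` has not yet been tested in this assay. It differs from compound 1 in one place: phenethyl in place of 4-methoxyphenyl on a saturated chain carbon bound to an oxygen on an unsaturated carbon. Because compound 1 reaches only the limit (the limit of >= 200000 nM in this assay, at which 1 of the 3 values shown sits), the step that the limit leaves unreadable from compound 1 to compound 4 is expected to be none beyond the scatter. Compound 4 is accordingly estimated at 300000 nM, with a range from 100000 nM to 600000 nM, and most probably it will again be reported as a limit.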

Compound 4, minimum cytotoxic concentration: >= 20000 nM
Compound 4 gave a limit, no number (the forecaster's own chance of this, stated with the estimate: 85%); the middle value does not contradict the limit.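

For the compounds shown here, no step from compound 1 to compound 4 can be read in this assay, as both values are limits and not numbers. The compounds shown leave open whether phenethyl in place of 4-methoxyphenyl changes cytotoxicity at all, and at what concentration, if any, either compound becomes cytotoxic.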